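The source may report more compounds than this note shows. Statements on the series, on what has been measured and on what is new or still open speak of the compounds shown alone.

Compound 1 `CCCCS(=O)(=O)Nc1cc(-c2ccc3ncnc(NCCN(C)C)c3c2)cnc1OC`: in a functional assay on SNU-638 cells (Homo sapiens) for antiproliferative activity, read by sulforhodamine B assay, with a stated time of 72 h (a higher number here means a weaker inhibitor, a lower number a stronger inhibitor), compound 1 gives 480 nM.
Compound 2 `COc1ncc(-c2ccc3ncnc(NCCN(C)C)c3c2)cc1NS(C)(=O)=O`: in this assay compound 2 gives 410 nM.
Compound 3 `COc1ncc(-c2ccc3ncnc(NCCN(C)C)c3c2)cc1NS(=O)(=O)c1ccc(F)cc1F`: in this assay compound 3 gives 620 nM.

These three compounds share one core and differ only in the group on the sulfonyl sulfur. Compound 3 has the highest of the three numbers, yet its step from compound 1, a 1.3-fold higher number from compound 1 to compound 3 (0.11 log units; within the scatter), and its step from compound 2, a 1.5-fold higher number from compound 2 to compound 3 (0.18 log units; within the scatter), both lie within the scatter, as does a 1.2-fold lower number from compound 1 to compound 2 (0.07 log units; within the scatter); the three cannot be ranked against one another.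

Compound 4 `COc1ncc(-c2ccc3ncnc(NCCCN(C)C)c3c2)cc1NS(=O)(=O)c1ccc(F)cc1F` keeps the 2,4-difluorophenyl of compound 3 and changes the other end of the molecule: (dimethylamino)methyl in place of dimethylamino on a saturated chain carbon, two bonds along the chain from a nitrogen on an aromatic ring. Within the data shown here, none of the measured steps touches this chain; all three concern the sulfonyl substituent and therefore give no direct guide. What they do show is that across these varied sulfonyl groups the numbers in this assay moved little. Among the measured compounds shown here, with no step bearing on the chain, the expectation for compound 4 is a number close to that of compound 3, no change at the digits printed from compound 3 to compound 4 (within the scatter), and nothing beyond the scatter. Compound 4 is accordingly estimated at 620 nM, within the range 250 nM to 1500 nM.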

Compound 4, half-maximal inhibitory concentration: 1260 nM
Beside the measured number, compound 4's estimate is 2.0-fold (0.31 log units) below it; the measured number falls inside the stated range.
By their numbers in this assay, from the lowest: compounds 2, 1 and 3 (each within the scatter of the next); then compound 4.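

In this assay, among these compounds, the length of the chain ending in the dimethylamino group does bear on the result: going from (2-(dimethylamino)ethyl)amino to (3-(dimethylamino)propyl)amino gives a 2.0-fold higher number from compound 3 to compound 4 (0.31 log units; beyond the scatter) and is the first step in this set to lie beyond the scatter, though only modestly. The exchanges on the sulfonyl sulfur among compounds 1, 2 and 3 all stayed within the scatter, whereas this small lengthening, on a saturated chain carbon two bonds along the chain from a nitrogen on an aromatic ring, did not, so this end of the molecule is the one of the two where a change has been seen to register. The finding rests on a single pair carrying the 2,4-difluorophenyl group, and nothing available explains why the number rose.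

The compounds shown leave open whether a still longer chain, such as 4-(dimethylamino)butyl, would raise the number further, and whether a morpholine in place of the dimethylamino group would change it. Also open, going by these compounds, is whether the same lengthening gives a step of similar size when methyl or butyl sits on the sulfonyl sulfur.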